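Moving bromine from 3-bromophenyl to 2-bromophenyl

The source may hold more compounds than are shown below. What is called first, only, known or untested is meant among the compounds shown, and "the series" means these compounds.

Compound 1 `COc1cc(OC)c(-c2coc3cc(OCc4ccccc4F)ccc3c2=O)cc1OC`: 2900 nM
Compound 2 `COc1cc(OC)c(-c2coc3cc(OCc4ccccc4C#N)ccc3c2=O)cc1OC`: > 10000 nM (a limit of the assay, not a number)
Compound 3 `COc1cc(OC)c(-c2coc3cc(OCc4cccc(Br)c4)ccc3c2=O)cc1OC`: 1200 nM

These three compounds were tested in a functional assay on HCT-116 cells (Homo sapiens) for antiproliferative activity, read by MTT assay, with a stated time of 24 h; on this read-out lower numbers stand for stronger inhibition and higher numbers for weaker inhibition. Compound 3 gives 1200 nM, the lower of the two actual numbers. Compound 1 stands nearest to it, with a 2.4-fold lower number from compound 1 to compound 3 (0.38 log units; beyond the scatter). Compound 4 `COc1cc(OC)c(-c2coc3cc(OCc4ccccc4Br)ccc3c2=O)cc1OC` has yet to be measured, and its change from compound 3 is 2-bromophenyl in place of 3-bromophenyl on a saturated chain carbon bound to an oxygen on an aromatic ring. The two have the same atoms, joined differently.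

Among the measured compounds shown here, no measured step isolates this change. The closest is a 2.4-fold lower number from compound 1 to compound 3 (0.38 log units; beyond the scatter), which brings 3-bromophenyl in place of 2-fluorophenyl and so alters the halogen as well. The step of an at least 8.3-fold lower number from compound 2 to compound 3 (0.92 log units; beyond the scatter) brings 3-bromophenyl in place of 2-cyanophenyl, but it rests on a limit and is only a bound on size. For the measured compounds named here, in both of these steps, leaving a 2-substituted phenyl lowers the number, although they cover only three compounds. Compound 4 reverses that kind of change while keeping the bromine, so a modest step to a higher number is expected in this assay, estimated as a 1.7-fold higher number from compound 3 to compound 4 (0.22 log units; within the scatter). For compound 4 the estimated value is 2000 nM, with an expected range of 700 nM to 6000 nM.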

Compound 4, half-maximal inhibitory concentration: 4550 nM
For compound 4 the middle estimate is 2.3-fold (0.36 log units) below the measured one; low and high end bracket the measured number.
By their numbers in this assay, from the lowest: compound 3; then compounds 1 and 4 (each within the scatter of the next). At a limit, above all of these: compound 2.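

In this assay, among the compounds shown here, with the bromine kept, a 3.8-fold higher number from compound 3 to compound 4 (0.58 log units; beyond the scatter) shows that the change between 3-bromophenyl and 2-bromophenyl alone moves the number beyond the scatter, a change that the earlier steps could not separate from a change of substituent. With the 2-substituted phenyl kept, a 1.6-fold higher number from compound 1 to compound 4 (0.20 log units; within the scatter) stays within the scatter, so these two compounds do not separate bromo from fluoro at this place. an at least 2.1-fold lower number from compound 2 to compound 4 (0.34 log units; beyond the scatter) gives only a bound on size for bromo in place of cyano, and compound 2 stands at a limit of the assay, not at a number: the limit of > 10000 nM in this assay, at which 1 of the 4 values shown sits.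

Fluoro and cyano each appear here only on a 2-substituted phenyl, so whether the same change of place would give a similar step with those groups remains open, and the compounds shown give no reason for the step. Also open, on these data alone, is how an amine or a carboxylic acid in place of the bromine, or a longer chain in place of the single saturated carbon bound to the oxygen, would read in this assay.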